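Swapping an aromatic amine for a dipropylamino chain

A few compounds are considered here, and "the series" means these few. Any claim that something is new, unique, unknown or untested is made for them only; others in the source may bear on it.

Compound 1 `COc1cccc(NC2=CC(=O)c3c(nc4n3[C@H]3OC[C@@H](O)[C@H]3OC4)C2=O)c1` and compound 2 `Cc1ccc(NC2=CC(=O)c3c(nc4n3[C@H]3OC[C@@H](O)[C@H]3OC4)C2=O)cc1` share one core and differ only in the group on the amine nitrogen. In a functional assay on MGC-803 cells (Homo sapiens) for inhibition, read by sulforhodamine B assay (on this read-out higher numbers stand for weaker inhibition and lower numbers for stronger inhibition), compound 1 gives 1790 nM, and compound 2 gives 1550 nM; the step of a 1.2-fold lower number from compound 1 to compound 2 (0.06 log units; within the scatter) is within the scatter, so compound 2 stands alongside compound 1 rather than apart from it. Compound 3 `CCCN(CCC)C1=CC(=O)c2c(nc3n2[C@H]2OC[C@@H](O)[C@H]2OC3)C1=O` carries dipropylamino in place of (4-methylphenyl)amino on a double-bonded ring carbon. Among the measured compounds shown here, no measured step exchanges an aromatic amine for a chain amine; the only step seen, one aromatic ring for another, was within the scatter and gives little guidance. With wide uncertainty, compound 3 is expected at 2500 nM, between 700 nM and 9000 nM, a step of a 1.6-fold higher number from compound 2 to compound 3 (0.21 log units; within the scatter) that is expected to stay modest.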

Compound 3, half-maximal inhibitory concentration: > 16000 nM
Compound 3: a limit, no number; the forecaster's own chance of this, stated with the estimate: 10%; at least 6.4-fold (0.80 log units) between middle value and limit.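

Among the earlier compounds, one aromatic ring on the amine nitrogen was exchanged for another, and their values stayed within the scatter of each other. Dipropylamino on the double-bonded ring carbon instead gives an at least 10-fold higher number from compound 2 to compound 3 (1.01 log units; beyond the scatter) and an at least 8.9-fold higher number from compound 1 to compound 3 (0.95 log units; beyond the scatter), so in this assay this position does not accept every amine alike. For compound 3 the value is a limit and not a number: the limit of > 16000 nM in this assay, at which 1 of the 3 values shown sits.

As far as these compounds go, compound 3 lacks both the aromatic ring and the hydrogen on the nitrogen, so which loss matters stays open. Propylamino, which keeps that hydrogen without a ring, and methyl(phenyl)amino, which keeps the ring without that hydrogen, would separate the two.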